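The source may hold more compounds than are shown below. What is called first, only, known or untested is meant among the compounds shown, and "the series" means these compounds.

Among the measured compounds shown here, compound 1 `O=C(OC1CC1)N1CCc2cc(C3(C(=O)Nc4ccc(F)cc4)CCC3)ccc21` is the only compound here that comes with a number: in an assay on blood for inhibition of Indoleamine 2,3-dioxygenase 1 (Homo sapiens) (on this read-out lower numbers stand for stronger inhibition and higher numbers for weaker inhibition), compound 1 gives 0.45 nM, a strong result. Compound 2 `Cc1nccc(N2CCc3nc(C4(C(=O)Nc5ccc(F)cc5)CCC4)ccc32)n1` shares much of its shape with compound 1 but carries a different group on the ring nitrogen of the fused system and a different core, and in this assay compound 2 has no reported result, recorded as "not determined" (no result reported), so it cannot be placed on the scale at all. Compound 3 `O=C(c1cccc(Cl)c1)N1CCc2nc(C3(C(=O)Nc4ccc(F)cc4)CCC3)ccc21` differs from compound 2 in one place: (3-chlorophenyl)carbonyl in place of 2-methylpyrimidin-4-yl on a nitrogen on an aromatic ring in a ring. With no number for compound 2, neither the size nor the direction of the step from compound 2 to compound 3 can be read from the data, and the only anchor remaining is the strong value of compound 1. On that basis alone, compound 3 is expected to land near 5 nM, within a range of 0.5 nM to 50 nM.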

Compound 3, half-maximal inhibitory concentration: 0.84 nM
The estimate for compound 3 lay 6.0-fold (0.77 log units) above the measured number; measured number inside the range.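

In this assay, among the compounds shown here, compound 2 has no number, and no step from compound 2 to compound 3 can be read. No other data here bear on this result. The compounds shown leave open what replacing 2-methylpyrimidin-4-yl with (3-chlorophenyl)carbonyl does to inhibition.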